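The compounds below may be only part of what the source reports. "The series", "measured", "known", "first", "only" and "open" are said of these compounds alone.

Going by the values given here, compound 1, with the structure `CC1CCN(c2c(S(=O)(=O)c3ccc(Cl)c(Cl)c3)cnc3ccc(Cl)cc23)CC1`, is the only compound of this set with a reported number: in a functional assay on the whole organism with Rattus norvegicus as the target (on this read-out lower numbers stand for an effect already at smaller amounts and higher numbers for an effect only at larger amounts of compound), compound 1 gives 30 mg/kg. A second compound, compound 2 with the structure `CC1CCN(c2c(S(=O)(=O)c3cc(F)cc(F)c3)cnc3cc(Cl)ccc23)CC1`, was made as well, but in this assay compound 2 has only the entry "not determined" (no result reported), so nothing can be compared between compound 1 and compound 2.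

Compound 3, with the structure `CC1CCN(c2c(S(=O)(=O)c3ccc(Cl)c(Cl)c3)cnc3ccc(F)cc23)CC1`, has not been measured. Set against compound 1 it differs in one place: fluoro in place of chloro on an aromatic carbon. Among the compounds with values here, a swap of one halogen for another at the same place on the shared core is a small change, and no measured pair here shows what such a swap does in this assay.

The step from compound 1 to compound 3 is expected to be small, no change at the digits printed from compound 1 to compound 3 (within the scatter), and to stay within the usual scatter. For compound 3 the estimated minimum effective dose in this assay is 30 mg/kg, with a range from 10 mg/kg to 100 mg/kg.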

Compound 3, minimum effective dose in the Rattus norvegicus assay: > 30 mg/kg
Compound 3: a limit, no number; the forecaster's own chance of this, stated with the estimate: 15%; the middle value lies on the limit itself.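

In the Rattus norvegicus assay, fluoro in place of chloro on an aromatic carbon of the shared core gives a number no lower from compound 1 to compound 3 (the limit leaves the size open), the first measured view of this change: it brings no lower effective dose, although the reading for compound 3 is a limit and not a number. In a physicochemical assay for solubility (on this read-out higher numbers stand for higher solubility and lower numbers for lower solubility), compound 1 gives < 3000 nM, which is a limit. In the physicochemical assay compound 3 gives < 3000 nM, also a limit, so no step can be read in either direction in this assay: the limit of < 3000 nM in the physicochemical assay, at which 2 of the 2 values shown sit.

From the compounds shown here alone, how far the effective dose of compound 3 lies from that of compound 1 stays open. Also open, going by these compounds, is what a group other than a halogen, such as an amine or a nitrile, would do at this place on the shared core.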